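Shortening the side chain of compound 1

The compounds below may be only part of what the source reports. "The series", "measured", "known", "first", "only" and "open" are said of these compounds alone.

Compound 1 `CCCCCCc1cc2cn(COCCO)c(=O)nc2o1` has been run in a functional assay on HEL cells (Homo sapiens), read by microscopy; a higher number here means that more compound is tolerated, a lower number that less compound is tolerated. In this assay compound 1 gives >= 400000 nM, which is a limit of the assay and not a number. Compound 2 `OCCOCn1cc2ccnc-2nc1O` carries a different core. In this assay compound 2 gives > 400000 nM, again a limit rather than a measured number. Both values therefore sit at the edge of what the assay reports, as shown by the limit of > 400000 nM in this assay, at which 1 of the 2 values shown sits, and (the limit of >= 400000 nM in this assay, at which 1 of the 2 values shown sits). Going by the values given here, no step between two measured compounds is available, so nothing about the effect of chain length has been measured directly.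

Compound 3 `CCCCc1cc2cn(COCCO)c(=O)nc2o1` is compound 1 with a shorter chain: hydrogen in place of ethyl on a saturated chain carbon, four bonds along the chain from an aromatic carbon. Compound 1 already sits at the limit >= 400000 nM. A shift would therefore only be detectable if compound 3 returned a measured number rather than a limit. The step of a number no higher from compound 1 to compound 3 (the limit leaves the size open) is expected, meaning no change beyond the scatter. For compound 3 the estimate in this assay is 400000 nM, within 200000 nM to 400000 nM, most likely reported once more as a limit.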

Compound 3, minimum cytotoxic concentration: > 400000 nM
Compound 3 was reported as a limit; the forecaster's own chance of this, stated with the estimate: 85%; the middle value sits exactly at the limit.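

In this assay compound 3 gives > 400000 nM, a limit of the assay and not a number. Compound 1 gives >= 400000 nM, likewise a limit. These two limits leave the step between compound 1 and compound 3 unreadable. On these data alone, whether any chain on the shared core would return a measured number in this assay stays open.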